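The compounds below may be only part of what the source reports. "The series", "measured", "known", "first", "only" and "open" are said of these compounds alone.

Compound 1 `O=C1C(Nc2ccc(I)cc2)=CC(=O)c2c1nc1n2[C@H]2OC[C@@H](O)[C@H]2OC1` gives 2530 nM in a functional assay on ECa-109 cells for inhibition, with ECa-109 cell line (Homo sapiens) as the target, read by sulforhodamine B assay (a lower number here means a stronger inhibitor, a higher number a weaker inhibitor), and sits alongside compound 3 `CCOc1ccc(NC2=CC(=O)c3nc4n(c3C2=O)[C@H]2OC[C@@H](O)[C@H]2OC4)cc1`, which gives 3210 nM, the gap between them lying within the scatter. Compound 2 `O=C1C=C(NC2CCCC2)C(=O)c2c1nc1n2[C@H]2OC[C@@H](O)[C@H]2OC1` reaches only the assay limit of > 16000 nM in this assay. Among the measured compounds shown here, the single measured step, an at least 4.9-fold lower number from compound 2 to compound 3 (0.69 log units; beyond the scatter), bears on the change at hand, and its size is known only as a bound because the limit of > 16000 nM in this assay, at which 1 of the 3 values shown sits, caps it. Compound 4 `O=C1C(N2CCC2)=CC(=O)c2c1nc1n2[C@H]2OC[C@@H](O)[C@H]2OC1` differs from compound 1 by azetidin-1-yl in place of (4-iodophenyl)amino on a double-bonded ring carbon, again replacing an aromatic amine with a small non-aromatic ring, as in the reverse of that step. A move toward the weaker side is therefore expected, with the expected step of a 5.9-fold higher number from compound 1 to compound 4 (0.77 log units; beyond the scatter) beyond the scatter. Compound 4 is estimated at 15000 nM, range 4000 nM to 60000 nM.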

Compound 4, half-maximal inhibitory concentration: > 16000 nM
Compound 4 was reported as a limit; the forecaster's own chance of this, stated with the estimate: 45%; middle value at least 1.0-fold (0.02 log units) away from the limit.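

The step of an at least 6.3-fold higher number from compound 1 to compound 4 (0.80 log units; beyond the scatter) extends the earlier finding to a second pair: the loss now appears on going from an aromatic amine to azetidin-1-yl, a non-aromatic ring with no donor on its nitrogen. Compound 2 and compound 4 cannot be ordered against each other, and the size of this step is a bound only because of the assay ceiling: the limit of > 16000 nM in this assay, at which 2 of the 4 values shown sit.

Compound 4 changes the aromatic ring and the amine hydrogen together, so which of the two matters stays unresolved. A benzylamino or morpholin-4-yl group at this carbon could help separate them.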